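Lengthening the Chain by One Carbon on the Urea

The source may report more compounds than this note shows. Statements on the series, on what has been measured and on what is new or still open speak of the compounds shown alone.

Compound 1 `Cc1cc(C(=O)O)nn1-c1ccc(S(=O)(=O)NC(=S)NC2CCCCC2)cc1`: 1%
Compound 2 `CCCCNC(=O)NS(=O)(=O)c1ccc(-n2nc(C)cc2C)cc1`: 2%
Compound 3 `CCCNC(=O)NS(=O)(=O)c1ccc(-n2nc(C(=O)O)cc2C)cc1`: 1%

In a functional assay on the whole organism (blood, strain albino) with Mus musculus as the target, with stated times of 6 days and 4 h, at a dose of 0.4 mmol/kg by the oral route (on this read-out lower numbers stand for less inhibition and higher numbers for more inhibition at the one dose given (going by the name of the read-out)), compound 3 gives 1%, level with compound 1 at the digits shown and together with it the lowest of the three numbers, while compound 2 sits within the scatter of both. Compound 4 `CCCCNC(=O)NS(=O)(=O)c1ccc(-n2nc(C(=O)O)cc2C)cc1` differs from compound 3 by methyl in place of hydrogen on a saturated chain carbon, three bonds along the chain from an amide-type nitrogen. For the measured compounds named here, no measured step changes a chain this way: the single step, no change at the digits printed from compound 1 to compound 3 (within the scatter), exchanges a different group on the sulfonamide nitrogen and stayed within the scatter. Compound 2 carries the butyl chain on another core and is also within the scatter of compound 3. The step is therefore expected to be a number 1 percentage points higher from compound 3 to compound 4 (within the scatter), nothing beyond the scatter. Compound 4 is estimated at 2%, ranging from 0% to 10%.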

Compound 4, a percentage reported as inhibition, in the whole organism at one dose (the size of the read-out at that dose, not a potency): 2%
Beside the measured number, compound 4's estimate shows no gap at the digits printed; the range from low to high includes it.
By their numbers in this assay, from the lowest: compounds 1, 3, 2 and 4 (each within the scatter of the next).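

In this assay, going from propyl to butyl gives a number 1 percentage points higher from compound 3 to compound 4 (within the scatter), so adding methyl at this chain carbon moves the number no further than the scatter. Carboxy in place of methyl on an aromatic carbon gives no change at the digits printed from compound 2 to compound 4 (within the scatter), and exchanging the whole group on the sulfonamide nitrogen gives a number 1 percentage points higher from compound 1 to compound 4 (within the scatter), so none of the three changes stands out from the scatter. No measurement here bears on why these numbers stay together. As far as these compounds go, whether a longer chain such as hexyl, or an amine on this chain, would move the number beyond the scatter remains open.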